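From 4-Nitrophenyl to 2-Nitrophenyl: One Group, Rearranged

The source may hold more compounds than are shown below. What is called first, only, known or untested is meant among the compounds shown, and "the series" means these compounds.

Of the compounds shown here, two that share a core have so far been tested in a functional assay on HeLa cells (Homo sapiens) for antiproliferative activity, read by MTT assay, with a stated time of 72 h; a higher number here means a weaker inhibitor, a lower number a stronger inhibitor. Compound 1 `Nc1nc(N)c2cc(CSC(=S)N3CCN(C4CCCCC4)CC3)ccc2n1`, which carries cyclohexyl on an amine nitrogen in a ring, gives 5960 nM. Compound 2 `Nc1nc(N)c2cc(CSC(=S)N3CCN(c4ccc([N+](=O)[O-])cc4)CC3)ccc2n1`, which carries 4-nitrophenyl at that place, gives 1660 nM, the lower of the two numbers and so the stronger result so far.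

The next compound, compound 3 `Nc1nc(N)c2cc(CSC(=S)N3CCN(c4ccccc4[N+](=O)[O-])CC3)ccc2n1`, has the same atoms as compound 2 joined differently, with 2-nitrophenyl in place of 4-nitrophenyl (2-nitrophenyl in place of 4-nitrophenyl on an amine nitrogen in a ring). Among the measured compounds shown here, only one measured step bears on this change, a 3.6-fold lower number from compound 1 to compound 2 (0.56 log units; beyond the scatter). That step is modest, and it replaced a whole group, so it offers only a rough guide to size. For the measured compounds named here, no measured pair shows what happens when the nitro group alone changes its place. A smaller step than that one is therefore expected in this assay, with a slight lean toward a higher number and little beyond the scatter. The estimated change is a 1.4-fold higher number from compound 2 to compound 3 (0.14 log units; within the scatter). The expected value for compound 3 is 2300 nM, within an estimated range of 850 nM to 6000 nM.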

Compound 3, half-maximal inhibitory concentration: 4880 nM
Beside the measured number, compound 3's estimate is 2.1-fold (0.33 log units) below it; measured number inside the range.
By their numbers in this assay, from the lowest: compound 2; then compounds 3 and 1 (each within the scatter of the next).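

Where the nitro group sits on the phenyl ring matters in this assay, even though the atom count stays the same: moving it gives a step beyond the scatter (a 2.9-fold higher number from compound 2 to compound 3 (0.47 log units; beyond the scatter)). Among the compounds shown here, this is the first direct look at the nitro group's place, and it shows that the group's atoms alone do not set the result. The second step lies within the scatter (a 1.2-fold lower number from compound 1 to compound 3 (0.09 log units; within the scatter)), so 2-nitrophenyl and cyclohexyl cannot be told apart here, and the advantage seen earlier belongs to 4-nitrophenyl rather than to every nitrophenyl group. Nothing available explains why the two arrangements differ.

A plain phenyl ring on the same nitrogen would help show whether the nitro group in compound 2 adds to the activity or whether the nitro group in compound 3 takes it away. On these data alone, it also remains open whether an amine or a nitrile in place of the nitro group would hold the level of compound 2 at 1660 nM or lose it.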